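This account rests on a few compounds, and the source may have more. Where it says the series, first, only, none or still open, it means among the compounds named here.

Compound 1: `C#CCOc1ccc(-c2cc(-c3ccccc3OCC#C)nc(-c3ccccc3)n2)cc1`; in an assay on BTI-TN-5B1-4 cells for inhibition of Amine oxidase [flavin-containing] B (Homo sapiens), read by fluorescence and Amplex Red, using microsomes, with a stated time of 30 min (a lower number here means a stronger inhibitor, a higher number a weaker inhibitor), compound 1 gives 14400 nM.
Compound 2: `C#CCOc1cccc(-c2cc(-c3cccc(OCC#C)c3)nc(-c3ccccc3)n2)c1`; in this assay compound 2 gives 23400 nM.
Compound 3: `C#CCOc1ccc(-c2cc(-c3ccc(OCC#C)c(OCC)c3)nc(-c3ccccc3)n2)cc1`; in this assay compound 3 gives 29000 nM.

All three numbers are close together. Compound 2 has the second highest of the three, but its gap to compound 3 and its gap to compound 1 both lie within the usual scatter of this assay, so none of the three can be called a stronger or weaker inhibitor than the others on these figures alone; all three are weak.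

The unmeasured compound 4, `C#CCOc1cccc(-c2cc(-c3cccc(OCC#C)c3)nc(N)n2)c1`, is derived from compound 2 by a single change: amino in place of phenyl on an aromatic carbon. The phenyl group that sits on the shared core of compound 2 is thus replaced by a much smaller group with one hydrogen-bond donor and one acceptor.

Among the compounds with values here, no pair of measured compounds differs in a comparable way, so there is no measured step to lean on. With compounds 1, 2 and 3 all weak and indistinguishable, the safest expectation is that compound 4 stays in the same weak region, and the expected step from compound 2 to compound 4 is a 1.3-fold higher number from compound 2 to compound 4 (0.11 log units; within the scatter), with wide uncertainty in either direction. Compound 4 is therefore estimated at 30000 nM in this assay, within a range from 8000 nM to 120000 nM.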

Compound 4, half-maximal inhibitory concentration: 22100 nM
Estimate against measurement, compound 4: 1.4-fold (0.13 log units) above; the measured number falls inside the stated range.
By their numbers in this assay, from the lowest: compounds 1, 4, 2 and 3 (each within the scatter of the next).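

Replacing the phenyl with amino, on the aromatic carbon between two ring nitrogen atoms, gives a 1.1-fold lower number from compound 2 to compound 4 (0.02 log units; within the scatter) in this assay. Within the data shown here, this is the only comparison here that changes a single place, and it shows that at this position a large carbon-only aromatic ring and a much smaller group carrying a hydrogen-bond donor and acceptor cannot be told apart in this read-out: the phenyl is not required for the weak inhibition seen, and the amino brings no measurable gain. The data shown offer no explanation for why the two groups read alike.

Two very different groups giving indistinguishable weak numbers leaves open whether any other group at this position, such as a methyl, a dimethylamino or a carboxylic acid, would move the number beyond the scatter. From the compounds shown here alone, whether amino would read the same on the core of compound 1, with its different arrangement of propargyloxy groups, also remains open.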